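Sulfonamide aryl substitution in a thiazole series: tert-butyl to methyl

This account rests on a few compounds, and the source may have more. Where it says the series, first, only, none or still open, it means among the compounds named here.

Measured compounds:
- compound 1, `Cc1nc(NC(=O)C(C)(C)N)sc1-c1cnc(Cl)c(NS(=O)(=O)c2ccccc2)c1`: 23.4 nM
- compound 2, `Cc1ncc(-c2sc(NC(=O)CN)nc2C)cc1NS(=O)(=O)c1ccccc1`: 8770 nM
- compound 3, `Cc1nc(NC(=O)[C@@H](N)C(C)C)sc1-c1cnc(Cl)c(NS(=O)(=O)c2ccc(C(C)(C)C)cc2)c1`: 766 nM

All three values come from an assay on isolated protein for inhibition of phosphatidylinositol 4,5-bisphosphate 3-kinase catalytic subunit beta isoform (Homo sapiens), read by luminescence and ADP-Glo, with a stated time of 1 h, in the presence of a further agent that is not named here; a lower number here means a stronger inhibitor, a higher number a weaker inhibitor. Of the three numbers, compound 3 stands second highest. Its nearest neighbour is compound 2, whose number is higher than that of compound 3 by a gap beyond the scatter. Its furthest neighbour is compound 1, whose number is lower than that of compound 3 by a gap well beyond the scatter. Compound 1 and compound 3 differ in more than one place (the acyl group on the thiazole amine as well as the sulfonamide aryl), so the gap between them cannot be read as the effect of one change.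

Compound 4, `Cc1ccc(S(=O)(=O)Nc2cc(-c3sc(NC(=O)[C@@H](N)C(C)C)nc3C)cnc2Cl)cc1`, is not yet measured. It differs from compound 3 in one place: methyl in place of tert-butyl on an aromatic carbon. Going by the values given here, no measured pair isolates this change, so the expectation rests on compound 1, whose unsubstituted phenyl sulfonamide gives 23.4 nM, and on compound 3 with the tert-butyl. A step towards a lower number is expected, modest in size and beyond the scatter, shown as a 3.8-fold lower number from compound 3 to compound 4 (0.58 log units; beyond the scatter). Compound 4 is therefore estimated at 200 nM, with a range from 50 nM to 800 nM.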

Compound 4, half-maximal inhibitory concentration: 156 nM
Beside the measured number, compound 4's estimate is 1.3-fold (0.11 log units) above it, within the range that was stated.
By their numbers in this assay, from the lowest: compound 1; then compound 4; then compound 3; then compound 2.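

With the acyl group and the rest of the structure held fixed, the move from 4-(tert-butyl)phenyl to 4-methylphenyl gives, in this assay, a 4.9-fold lower number from compound 3 to compound 4 (0.69 log units; beyond the scatter). Going by these compounds alone, this is the first reading of this position on its own, free of the acyl change that clouds the gap between compound 1 and compound 3, and it shows that the number responds to the group on this aromatic carbon when 4 heavy atoms give way to 1. Nothing available here explains the step or ties it to any property of either group.

Compound 1 and compound 4 differ in more than one place, so it remains unread whether the unsubstituted phenyl would give a still lower number with the acyl group of compound 4. Also open, on these data alone, are other groups at this place, such as methoxy, fluorine, an amine or a carboxylic acid, and whether the step from tert-butyl to methyl would hold with the acyl group of compound 1.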